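This account rests on a few compounds, and the source may have more. Where it says the series, first, only, none or still open, it means among the compounds named here.

Among the three measured analogues, compound 2 `C=CCN(CCC)Cc1c(C(F)(F)F)nc2n(-c3c(C)cc(C)cc3C)c(Cl)cn12` holds the lowest number in an assay on cells for displacement of a labelled ligand from corticotropin-releasing factor receptor 1 (Homo sapiens), with a stated time of 100 min (on this read-out lower numbers stand for stronger inhibition and higher numbers for weaker inhibition), giving 4.5 nM. Compound 1 `CCCCN(C)Cc1c(C(F)(F)F)nc2n(-c3c(C)cc(C)cc3C)c(Cl)cn12` gives 310 nM and compound 3 `C=C(C)CN(CC)Cc1c(C(F)(F)F)nc2n(-c3c(C)cc(C)cc3C)c(Cl)cn12` gives 67 nM; the gaps are a 69-fold lower number from compound 1 to compound 2 (1.84 log units; beyond the scatter), a 15-fold higher number from compound 2 to compound 3 (1.17 log units; beyond the scatter) and a 4.6-fold lower number from compound 1 to compound 3 (0.67 log units; beyond the scatter), each beyond the scatter, so the amine substituents clearly matter here. Compound 4 `CCCN(Cc1ccc(F)cc1)Cc1c(C(F)(F)F)nc2n(-c3c(C)cc(C)cc3C)c(Cl)cn12` is compound 2 with 4-fluorophenyl in place of vinyl on a saturated chain carbon bound to an amine nitrogen, leaving the propyl group untouched. Among the compounds with values here, no measured step trades an alkenyl group for an aromatic ring, so the direction of this change rests only on the general sensitivity of the amine position seen in those three steps, which were modest to large. The benzyl group is considerably larger than what it replaces, and on that basis a weakening beyond the scatter is expected, though with wide uncertainty. For compound 4 the expected value in this assay is 25 nM, with a range from 4 nM to 150 nM, which would be a step of a 5.6-fold higher number from compound 2 to compound 4 (0.74 log units; beyond the scatter).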

Compound 4, inhibition constant: 350 nM
For compound 4 the middle estimate is 14-fold (1.15 log units) below the measured one; measured number above the stated range.
By their numbers in this assay, from the lowest: compound 2; then compound 3; then compounds 1 and 4 (each within the scatter of the next).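

Replacing allyl with 4-fluorobenzyl while keeping the propyl group gives a 78-fold higher number from compound 2 to compound 4 (1.89 log units; beyond the scatter) in this assay. This is the first step shown that places an aromatic ring on the amine, and it shows that this ring, entering on a saturated chain carbon bound to an amine nitrogen, does not preserve the low number of compound 2. Nothing available explains why this change has so large an effect on the number.

The compounds shown leave open whether the loss goes with the six-membered aromatic ring itself or with its fluorine, a question that a plain benzyl group would address. They also leave open how a cyclopropylmethyl group or a butyl chain in the same place, alongside the propyl group, would read in this assay.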